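Benzodioxin to tetrahydronaphthalene: cytotoxicity outlook

The compounds below may be only part of what the source reports. "The series", "measured", "known", "first", "only" and "open" are said of these compounds alone.

Compound 1 `O=C(c1ccc2c(c1)OCCO2)C1CCN(Cc2coc(-c3cccc(F)c3)n2)CC1` gives > 150 ug/mL in an ADME assay on HEK293 cells (Homo sapiens) for cytotoxicity, read by MTT assay, with a stated time of 36 h (on this read-out higher numbers stand for weaker inhibition and lower numbers for stronger inhibition), a limit of the assay rather than a number.
Compound 2 `CC(C)(C)c1ccc(-c2nc(CN3CCC(C(=O)c4ccc5c(c4)OCCO5)CC3)co2)cc1` gives > 150 ug/mL in this assay, likewise a limit.
Compound 3 `O=C(c1ccc2c(c1)OCCO2)C1CCN(Cc2coc(-c3cccnc3)n2)CC1` gives > 150 ug/mL in this assay, again a limit.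

Compound 2 thus stands where every measured value sits, at the limit of > 150 ug/mL in this assay, at which 3 of the 3 values shown sit. Between the measured compounds, the steps a step that the two limits leave unreadable from compound 1 to compound 2, a step that the two limits leave unreadable from compound 1 to compound 3 and a step that the two limits leave unreadable from compound 2 to compound 3 cannot be read, since both ends are limits. Compound 4 `CC(C)(C)c1ccc(-c2nc(CN3CCC(C(=O)c4ccc5c(c4)CCCC5)CC3)co2)cc1` introduces a change elsewhere: 1,2,3,4-tetrahydronaphthalen-6-yl in place of 2,3-dihydro-1,4-benzodioxin-6-yl on a carbonyl carbon. Among the measured compounds shown here, no measured step touches that carbonyl substituent, so nothing in the data points to a readable shift. Compound 4 is therefore expected to remain at the limit, with an estimated 180 ug/mL in this assay, between 100 ug/mL and 320 ug/mL. The expected step is a step that the limit leaves unreadable from compound 2 to compound 4.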

Compound 4, half-maximal inhibitory concentration: > 150 ug/mL
Compound 4: no number, only a limit; the forecaster's own chance of this, stated with the estimate: 80%; the middle value is on the limit's open side.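

Compound 4 gives > 150 ug/mL in this assay, again a limit and not a number, so its step from compound 2 cannot be read. The compounds shown leave open whether either ring group changes cytotoxicity at all.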